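The compounds below may be only part of what the source reports. "The series", "measured", "known", "first", "only" and "open" are said of these compounds alone.

Going by the values given here, compound 2 `COc1nc2ccc(Br)cc2cc1C(c1ccccc1)n1cc(CCO)nn1` is one of two compounds measured in an ADME assay on SK-OV-3 cells (Homo sapiens) for cytotoxicity, read by sulforhodamine B assay, with a stated time of 48 h, tested at 10 uM; a higher number here means more inhibition at the concentration tested (going by the name of the read-out), a lower number less inhibition. In this assay compound 2 gives 8.46%, the lower of the two numbers, and compound 1 `CCCCCCCc1cn(C(c2ccccc2)c2cc3cc(Br)ccc3nc2OC)nn1` gives 10.5%. The step between them, a number 2 percentage points lower from compound 1 to compound 2 (within the scatter), lies within the scatter, so the two compounds cannot be told apart on these numbers.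

Compound 3 `COc1nc2ccc(Br)cc2cc1C(c1ccccc1)n1cc(-c2ccccc2C(F)(F)F)nn1` is not yet measured. It differs from compound 2 in one place: 2-(trifluoromethyl)phenyl in place of 2-hydroxyethyl on an aromatic carbon. Among the compounds with values here, the only measured step that bears on this change is the one from compound 1 to compound 2, where the group on the same aromatic carbon of the shared core was exchanged and the read-out moved by a number 2 percentage points lower from compound 1 to compound 2 (within the scatter), within the scatter. That step shows that one exchange at this position left the read-out where it was; it does not show what a 2-(trifluoromethyl)phenyl in place of 2-hydroxyethyl would do. On this basis the step from compound 2 to compound 3 is expected to be a number 3.5 percentage points higher from compound 2 to compound 3 (within the scatter), not beyond the scatter, and compound 3 is estimated at 12%, with a range from 0% to 30%.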

Compound 3, a percentage reported as inhibition, at one concentration (the size of the read-out at that concentration, not a potency): 9.55%
Compound 3: middle estimate off by 2.5 percentage points, on the high side; the measured number falls inside the stated range.
By their numbers in this assay, from the lowest: compounds 2, 3 and 1 (each within the scatter of the next).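

In this assay, putting 2-(trifluoromethyl)phenyl on the aromatic carbon of the five-membered ring gives a number 1.1 percentage points higher from compound 2 to compound 3 (within the scatter) and, measured against the heptyl compound, a number 1 percentage points lower from compound 1 to compound 3 (within the scatter) in the same assay. The position has now carried a six-membered aromatic ring of carbon only as well as two open chains, and the earlier pair, which differed only in its chains, could not speak to a ring at this place: all three groups give numbers within the scatter of one another, so the read-out does not separate the ring from either chain. Nothing at hand offers a reason for this lack of separation, and the result describes only what was read at the single concentration tested.

What stays open is whether any group on this carbon can move the read-out beyond the scatter, for instance an amine or a carboxylic acid, which would put a group of a different kind there than the chains and the aryl ring shown. The three compounds also share the rest of the core unchanged, so they say nothing about the bromine, the methoxy group or the phenyl on the central carbon.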